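From 2-bromobenzyl to 4-bromobenzyl

The compounds below may be only part of what the source reports. "The series", "measured", "known", "first", "only" and "open" are said of these compounds alone.

Compound 1 `Clc1ccccc1CSc1nnc(-c2ccc3c(c2)OCCO3)n1-c1ccccc1`: 9670 nM
Compound 2 `Brc1ccccc1CSc1nnc(-c2ccc3c(c2)OCCO3)n1-c1ccccc1`: 7350 nM

Both numbers come from a functional assay on SW 1116 cells (Homo sapiens) for antiproliferative activity, read by MTT assay, with a stated time of 24 h; a lower number here means a stronger inhibitor, a higher number a weaker inhibitor. The pair differ by bromo in place of chloro on an aromatic carbon, and the two values cannot be told apart, so compound 2 stands level with compound 1.

Compound 3 `Brc1ccc(CSc2nnc(-c3ccc4c(c3)OCCO4)n2-c2ccccc2)cc1` has not been measured. It has 4-bromophenyl in place of 2-bromophenyl on a saturated chain carbon bound to a sulfur.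

Within the data shown here, the only measured step is a 1.3-fold lower number from compound 1 to compound 2 (0.12 log units; within the scatter). Among the measured compounds shown here, it swaps one halogen for another and does not test this change, so it is a weak guide, and no measured compound carries 4-bromophenyl. With nothing pointing either way in this assay, no shift beyond the scatter is expected: a 1.1-fold lower number from compound 2 to compound 3 (0.02 log units; within the scatter). For compound 3 the estimated value is 7000 nM, with an expected range of 2500 nM to 20000 nM.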

Compound 3, half-maximal inhibitory concentration: 5810 nM
Estimate against measurement, compound 3: 1.2-fold (0.08 log units) above; measured number inside the range.
By their numbers in this assay, from the lowest: compounds 3, 2 and 1 (each within the scatter of the next).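

Moving the bromine from 2-bromobenzyl to 4-bromobenzyl changes where the halogen sits, which the swap of one halogen for another did not test, and in this assay it gives a 1.3-fold lower number from compound 2 to compound 3 (0.10 log units; within the scatter) with no real separation. Changing both the halogen and its place together gives a 1.7-fold lower number from compound 1 to compound 3 (0.22 log units; within the scatter) and also stays within the scatter, so this assay cannot tell these three benzyl groups apart. No evidence is available to explain these results.

As far as these compounds go, all three compounds carry a single halogen on the benzyl group, so it remains open whether a methoxy group or a nitrile there would move the number beyond the scatter. From the compounds shown here alone, it is equally open what an amine or a longer chain in place of the benzyl group on the sulfur would do.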